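The compounds below may be only part of what the source reports. "The series", "measured", "known", "first", "only" and "open" are said of these compounds alone.

Among the compounds with values here, in a functional assay on brain (Rattus norvegicus, strain Wistar) for inhibition (a higher number here means a weaker inhibitor, a lower number a stronger inhibitor), compound 1 `Cc1[nH]c(=O)n(C2CCCCC2)c1-c1ccccc1` gives 47600 nM and compound 2 `Cc1[nH]c(=O)n(C2CCCCC2)c1-c1ccc(OC(C)C)cc1` gives 13000 nM as the lower of the two numbers so far. Compound 3 `CCCCCOc1ccc(-c2c(C)[nH]c(=O)n2C2CCCCC2)cc1` differs from compound 2 by pentyl in place of isopropyl on an oxygen on an aromatic ring with pentyl in place of isopropyl on an oxygen on an aromatic ring. Within the data shown here, only one measured step bears on this change: a 3.7-fold lower number from compound 1 to compound 2 (0.56 log units; beyond the scatter) with isopropoxy in place of hydrogen on an aromatic carbon. From that single step, a further modest move to a lower number is expected in this assay with little certainty. The expected size is a 2.2-fold lower number from compound 2 to compound 3 (0.34 log units; beyond the scatter) on this reading. Compound 3 is estimated at 6000 nM with a range of 2000 nM to 16000 nM for now.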

Compound 3, half-maximal inhibitory concentration: 9100 nM
Compound 3: middle estimate off by 1.5-fold (0.18 log units), on the low side, and the stated range covers the measured number.
By their numbers in this assay, from the lowest: compounds 3 and 2 (each within the scatter of the next); then compound 1.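

In this assay the change from isopropoxy to pentyloxy reads a 1.4-fold lower number from compound 2 to compound 3 (0.15 log units; within the scatter) and so does not separate the two chains at this place on the aromatic ring. Pentyloxy in place of hydrogen gives a 5.2-fold lower number from compound 1 to compound 3 (0.72 log units; beyond the scatter) and is thus a second group on this aromatic carbon, after isopropoxy, that stands clear of hydrogen. Open, on these data alone, is whether a chain longer than pentyl, or an amine or a carboxylic acid at the end of the chain, would shift the number. No measurement at hand speaks to why these steps come out as they do.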